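A few compounds are considered here, and "the series" means these few. Any claim that something is new, unique, unknown or untested is made for them only; others in the source may bear on it.

Among the compounds with values here, in a functional assay on HepG2 cells (Homo sapiens) for inhibition, read by MTT assay, with a stated time of 120 h (a lower number here means a stronger inhibitor, a higher number a weaker inhibitor), compound 2 `O=C(/C=C/c1ccc(NC(=O)Nc2ccc(Cl)c(C(F)(F)F)c2)cc1)NC1CCC1` gives 7510 nM, the only number in the set. Compound 1 `CNC(=O)/C=C(\C)c1ccc(NC(=O)Nc2ccc(Cl)c(C(F)(F)F)c2)cc1` reaches only a limit in this assay, > 50000 nM. Its position is the limit of > 50000 nM in this assay, at which 1 of the 2 values shown sits, not a number. Within the data shown here, the single measured step, an at least 6.6-fold lower number from compound 1 to compound 2 (0.82 log units; beyond the scatter), is the only comparison that bears on compound 3 `CNC(=O)CCc1ccc(NC(=O)Nc2ccc(Cl)c(C(F)(F)F)c2)cc1`, which carries 2-(methylcarbamoyl)ethyl in place of 2-(cyclobutylcarbamoyl)ethenyl on an aromatic carbon. Compound 3 gives up the four-membered ring and one double bond that entered with that step, so a move back towards weaker inhibition is expected, with a 4.0-fold higher number from compound 2 to compound 3 (0.60 log units; beyond the scatter). Compound 3 is estimated at 30000 nM, within 9000 nM to 100000 nM.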

Compound 3, half-maximal inhibitory concentration: 21000 nM
Compound 3: middle estimate off by 1.4-fold (0.15 log units), on the high side; measured number inside the range.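

In this assay, 2-(methylcarbamoyl)ethyl at this position still gives a measured number, but with a 2.8-fold higher number from compound 2 to compound 3 (0.45 log units; beyond the scatter), so it ranks behind 2-(cyclobutylcarbamoyl)ethenyl. Replacing 1-methyl-2-(methylcarbamoyl)ethenyl with the same group gives an at least 2.3-fold lower number from compound 1 to compound 3 (0.37 log units; beyond the scatter). Compound 1 stands only at a limit, so this step is a bound and not a measured size: the limit of > 50000 nM in this assay, at which 1 of the 3 values shown sits.

The compounds shown leave open whether the four-membered ring or the ethenyl double bond accounts for the step to compound 3, as the two change together. Also open, as far as these compounds go, is how a carboxylic acid or an amine in place of this amide would read.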